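Replacing the amide substituent of compound 1

The source may report more compounds than this note shows. Statements on the series, on what has been measured and on what is new or still open speak of the compounds shown alone.

Going by the values given here, in a functional assay on MIA PaCa-2 cells (Homo sapiens) for inhibition, read by MTT assay, with a stated time of 7 days (a lower number here means a stronger inhibitor, a higher number a weaker inhibitor), compound 1 (`CCN(CC)S(=O)(=O)c1ccc(S(=O)(=O)N2CCC[C@@H](C(=O)N[C@H]3CC[C@H](OC)CC3)C2)cc1`) gives 1350 nM and holds the higher of the two numbers so far, while compound 2 (`O=C([C@@H]1CCCN(S(=O)(=O)c2ccc(S(=O)(=O)C3COC3)cc2)C1)N1CCC(F)(F)CC1`) gives 110 nM and lies lower by a gap beyond the scatter. Compound 1 is therefore the weaker inhibitor of this pair. However, the two compounds differ in more than one place, so their gap cannot be tied to any single change.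

Compound 3 (`CCN(CC)S(=O)(=O)c1ccc(S(=O)(=O)N2CCC[C@@H](C(=O)NC3CCOCC3)C2)cc1`) keeps the core of compound 1 and carries oxan-4-yl in place of 4-methoxycyclohexyl on an amide-type nitrogen. Among the compounds with values here, no measured pair here isolates a change of this kind, so the expectation rests on compound 1 and the structural change alone. Both the group that leaves and the group that enters hold one six-membered non-aromatic ring and one hydrogen-bond acceptor. The expected step (a 1.3-fold higher number from compound 1 to compound 3 (0.12 log units; within the scatter)) is estimated to stay within the scatter in this assay with only a slight lean towards a weaker inhibitor. Compound 3 is expected at 1800 nM with an estimated range from 600 nM to 5500 nM in this measurement.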

Compound 3, half-maximal inhibitory concentration: 3770 nM
For compound 3 the middle estimate is 2.1-fold (0.32 log units) below the measured one, within the range that was stated.
By their numbers in this assay, from the lowest: compound 2; then compound 1; then compound 3.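

In this assay, the amide-type nitrogen of compound 1 proves responsive to an exchange that looks minor on paper: oxan-4-yl in place of 4-methoxycyclohexyl gives a 2.8-fold higher number from compound 1 to compound 3 (0.45 log units; beyond the scatter), a modest step and the first difference here that can be tied to one place. Both groups hold one six-membered non-aromatic ring, no hydrogen-bond donors and one hydrogen-bond acceptor, so these shared counts do not make the two groups interchangeable at this position. The entering group also differs in having 6 heavy atoms rather than 8, its oxygen in the ring and no defined stereocentres, but no measurement shown assigns the step to any one of these differences.

The compounds shown leave open how this position responds to a plain cyclohexyl group, which carries no oxygen, or to a six-membered ring bearing an amine or a carboxylic acid. They also leave open whether the same exchange on the amide-type nitrogen would give a step of similar size on a different core.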